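The source may report more compounds than this note shows. Statements on the series, on what has been measured and on what is new or still open speak of the compounds shown alone.

Compound 1, `Cn1cccc1-c1cc(-c2cccs2)nc(N)c1C#N`: in a functional assay on SF-539 cells (Homo sapiens) for inhibition, read by sulforhodamine B assay, with a stated time of 48 h (on this read-out lower numbers stand for stronger inhibition of growth and higher numbers for weaker inhibition of growth), compound 1 gives > 100000 nM, a limit of the assay and not a number.
Compound 2, `CC1CCCc2c1[nH]c(=O)c(C#N)c2-c1cccn1C`: in this assay compound 2 gives > 100000 nM, again a limit of the assay.
Compound 3, `Cn1cccc1-c1cc(-c2ccccc2)[nH]c(=O)c1C#N`: in this assay compound 3 gives > 100000 nM, once more a limit of the assay.

Compound 1 therefore stands nowhere in particular among the numbers shown: all three measured compounds sit at the same limit, as stated in the limit of > 100000 nM in this assay, at which 3 of the 3 values shown sit, so no ordering among them can be read off, and no step between any two measured compounds is available.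

Compound 4, `Cn1cccc1-c1cc(-c2ccccc2)nc(N)c1C#N`, is the compound that remains unmeasured. It differs from compound 1 in one place only: phenyl in place of thiophen-2-yl on an aromatic carbon. Among the measured compounds shown here, with no measured step to lean on, and with compound 1 itself only a limit, the expectation is that the change makes no difference beyond the scatter, and the step from compound 1 to compound 4 in this assay is estimated as a step that the limit leaves unreadable from compound 1 to compound 4. Compound 4 is thus expected to show 150000 nM in this assay, within a range from 40000 nM to 600000 nM, most likely reported again only as a limit.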

Compound 4, concentration for 50% growth inhibition: 33900 nM
Compound 4: the middle estimate sits 4.4-fold (0.65 log units) above what was measured; measured number outside the range, below it.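

Phenyl in place of thiophen-2-yl, on the aromatic carbon next to the ring nitrogen, gives an at least 2.9-fold lower number from compound 1 to compound 4 (0.46 log units; beyond the scatter) in this assay. This is the first sign among the compounds shown that the group at this position can change growth inhibition, and the printed step is a minimum, not an exact size. Even so, the change stands alone, and most of the values still give no number to compare: the limit of > 100000 nM in this assay, at which 3 of the 4 values shown sit.

Among the compounds shown here, what remains open is whether this change reflects something particular to phenyl, since only two groups have been compared here. A methoxy group or a chlorine on the phenyl ring, or a pyridin-3-yl ring in its place, could move the number further in either direction, and the compounds shown cannot say which.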